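A few compounds are considered here, and "the series" means these few. Any claim that something is new, unique, unknown or untested is made for them only; others in the source may bear on it.

Measured compounds:

Compound 1, `N#Cc1cc2cc(-c3ccccc3)n(O)c2cc1C#N`, 10300 nM
Compound 2, `Cc1ccc(-c2cc3cc(C#N)c(C#N)cc3n2O)cc1`, 821 nM
Compound 3, `COn1c(-c2ccccc2)c(C=O)c2cc(C#N)c(C#N)cc21`, for which only a limit is known, > 100000 nM

All three were tested in an assay on isolated protein for inhibition of Amine oxidase [flavin-containing] B (Homo sapiens), read by fluorescence and spectrophotometry, with a stated time of 20 min; on this read-out lower numbers stand for stronger inhibition and higher numbers for weaker inhibition. Compound 1 and compound 2 share one core and differ in a single place: methyl in place of hydrogen on an aromatic carbon
This change gave a 13-fold lower number from compound 1 to compound 2 (1.10 log units; beyond the scatter), a clear gain in potency for compound 2.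

Compound 3 carries a different core; the difference between the two cores is not broken down here. For compound 3 the value is a limit of this assay, not a number, and it sits at the limit of > 100000 nM in this assay, at which 1 of the 3 values shown sits, so no potency can be read from it beyond that bound.

Compound 4, `COn1c(-c2ccc(C)cc2)c(C=O)c2cc(C#N)c(C#N)cc21`, has not yet been measured. It is related to compound 3 in the same way that compound 2 is related to compound 1: methyl in place of hydrogen on an aromatic carbon
Whether the same change produces the same gain on the second core is what the measurement will show. If the methyl acts as it did from compound 1 to compound 2, a step of an at least 2.0-fold lower number from compound 3 to compound 4 (0.30 log units; that floor lies within the scatter) is expected, an estimate resting on the one measured step of a 13-fold lower number from compound 1 to compound 2 (1.10 log units; beyond the scatter). Because compound 3 gives only the limit > 100000 nM, the starting point is uncertain, and compound 4 may itself end at the limit. For compound 4 a value near 50000 nM is estimated, with a plausible span from 8000 nM to 300000 nM.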

Compound 4, half-maximal inhibitory concentration: 74800 nM
Compound 4: the middle estimate sits 1.5-fold (0.17 log units) below what was measured, and the stated range covers the measured number.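

In this assay, the change from phenyl to 4-methylphenyl on the second core gives an at least 1.3-fold lower number from compound 3 to compound 4 (0.12 log units; that floor lies within the scatter) and so does not contradict the direction seen on the first core, but this figure is only a floor and does not establish the size of the step. On these data alone, compound 3 stands at a limit of the assay, > 100000 nM, and not at a number, so how far the methyl really moves the value on this core stays unknown. The result therefore shows neither that the methyl carries over with the same size nor that its effect shrinks on the second core: the same change on two cores in this assay, a 13-fold lower number (1.10 log units; beyond the scatter) from compound 1 to compound 2 and an at least 1.3-fold lower number (0.12 log units; that floor lies within the scatter) from compound 3 to compound 4; the limit leaves it open whether they differ.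

The compounds shown leave open whether a group other than methyl in the same place on the ring, such as an ethyl chain, a chlorine atom or an amine, would follow the same course on both cores. Among the compounds shown here, they also leave open which part of the difference between the two cores goes with the higher numbers on the second one, as no compound here separates the parts of that difference from each other.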